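Furan-2-yl in Place of Phenyl on a Hydroxyphenyl Pyridine Core

A few compounds are considered here, and "the series" means these few. Any claim that something is new, unique, unknown or untested is made for them only; others in the source may bear on it.

Compound 1 `Oc1ccc(-c2cc(-c3ccccc3)nc(-c3ccccc3Cl)c2)cc1` gives 2800 nM in a functional assay on DU-145 cells (Homo sapiens) for cytotoxicity, read by CCK-8 assay and cell counting, with a stated time of 2 days (a higher number here means a weaker inhibitor, a lower number a stronger inhibitor), the lower of the two numbers recorded, while compound 3 `Oc1cccc(-c2cc(-c3ccc(Cl)cc3)nc(-c3cccnc3)c2)c1` gives 26800 nM, a gap beyond the scatter. Compound 2 `Oc1cccc(-c2cc(-c3cccc(Cl)c3)nc(-c3ccccn3)c2)c1` gives "not determined" (no result reported) in this assay, so no number stands for it there. Among the measured compounds shown here, no two of these measured compounds differ in only one place, so no single step is known for this assay. Compound 4 `Oc1ccc(-c2cc(-c3ccco3)nc(-c3ccccc3Cl)c2)cc1` differs from compound 1 by furan-2-yl in place of phenyl on an aromatic carbon. For the measured compounds named here, with no measured step to lean on, the change from compound 1 to compound 4 is expected to be small, at most a modest weakening, as a 1.4-fold higher number from compound 1 to compound 4 (0.15 log units; within the scatter). Compound 4 is therefore estimated at 4000 nM, within a range from 1200 nM to 13000 nM.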

Compound 4, half-maximal inhibitory concentration: 5300 nM
For compound 4 the middle estimate is 1.3-fold (0.12 log units) below the measured one, within the range that was stated.
By their numbers in this assay, from the lowest: compounds 1 and 4 (each within the scatter of the next); then compound 3.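

Furan-2-yl in place of phenyl, on the aromatic carbon next to the ring nitrogen, gives a 1.9-fold higher number from compound 1 to compound 4 (0.28 log units; within the scatter) in this assay, the only single step known in this assay. At this position, a five-membered aromatic ring with one oxygen therefore cannot be told apart from the six-membered carbon ring. No evidence is available to explain this result.

The compounds shown leave open whether an amine or a carboxylic acid at this position would also stay within the scatter. From the compounds shown here alone, whether the same exchange would hold on the cores of compound 2 and compound 3 also remains open.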